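The source may report more compounds than this note shows. Statements on the series, on what has been measured and on what is new or still open speak of the compounds shown alone.

Working notes on the series. Compound 1 `COC(=O)c1cc(-c2cccc(NC(=O)c3ccc(/C=C/C(=O)c4cccs4)cc3)c2)on1` carries thiophen-2-yl on the carbonyl carbon; in an ADME assay on Vero cells (Chlorocebus sabaeus) for cytotoxicity, read by MTT assay, with a stated time of 72 h (on this read-out lower numbers stand for higher toxicity in this test and higher numbers for lower toxicity in this test), compound 1 gives "not determined" (no result reported), so it stands on no number of its own. Compound 2 `COC(=O)c1cc(-c2cccc(NC(=O)c3ccc(/C=C/C(=O)c4ccc(OC)cc4)cc3)c2)on1` carries 4-methoxyphenyl there. In this assay compound 2 reports only a limit, > 10 ug/mL. Compound 3 `COC(=O)c1cc(-c2cccc(NC(=O)c3ccc(/C=C/C(=O)c4ccc(F)cc4F)cc3)c2)on1` carries 2,4-difluorophenyl there. In this assay compound 3 likewise reports only a limit, > 40 ug/mL. Going by the values given here, the sole measured step, a step that the two limits leave unreadable from compound 2 to compound 3, sits between the limit of > 10 ug/mL in this assay, at which 1 of the 3 values shown sits, and the limit of > 40 ug/mL in this assay, at which 1 of the 3 values shown sits, and its size cannot be read. Compound 4 `COC(=O)c1cc(-c2cccc(NC(=O)c3ccc(/C=C/C(=O)c4ccc(OC)cc4OC)cc3)c2)on1` differs from compound 1 by 2,4-dimethoxyphenyl in place of thiophen-2-yl on a carbonyl carbon. Among the compounds with values here, no measured step bears on this change, so no direction beyond the scatter in this assay is expected. Compound 4 is estimated at 40 ug/mL in this assay, expected between 15 ug/mL and 100 ug/mL.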

Compound 4, half-maximal cytotoxic concentration: > 50 ug/mL
Compound 4: no number, only a limit; the forecaster's own chance of this, stated with the estimate: 60%; at least 1.2-fold (0.09 log units) between middle value and limit.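

Going by these compounds alone, compound 2, compound 3 and compound 4 each report only a limit in this assay, so no step among them can be read. Where their actual cytotoxic concentrations lie, and how the carbonyl-carbon group affects them, remains open.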